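Side-chain swap at the aminoacyl position of compound 2

The compounds below may be only part of what the source reports. "The series", "measured", "known", "first", "only" and "open" are said of these compounds alone.

Of the compounds shown here, three have numbers so far. Compound 1 `CSCC[C@H](N)C(=O)NS(=O)(=O)OC[C@H]1OC[C@@H](n2cnc3c(N)ncnc32)C[C@@H]1O` gives 5500 nM in a functional assay on PBMC cells (Homo sapiens) for inhibition; a higher number here means a weaker inhibitor, a lower number a stronger inhibitor; compound 3 `CSCC[C@H](N)C(=O)NS(=O)(=O)OC[C@H]1OC[C@@H](n2cnc3c(N)ncnc32)[C@H](O)[C@@H]1O` gives 5200 nM in this assay; compound 2 `CC(C)[C@H](N)C(=O)NS(=O)(=O)OC[C@H]1O[C@@H](n2cnc3c(N)ncnc32)[C@H](O)[C@@H]1O` gives 5600 nM in this assay. Compound 2 stands highest of the three numbers, but its gap to compound 1 and to compound 3 lies within the scatter, so the three read as a single level. Among the measured compounds shown here, the only single-point step among them, a 1.1-fold lower number from compound 1 to compound 3 (0.02 log units; within the scatter), is likewise within the scatter.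

Compound 4 `NC(=O)CC[C@H](N)C(=O)NS(=O)(=O)OC[C@H]1O[C@@H](n2cnc3c(N)ncnc32)[C@H](O)[C@@H]1O` has not yet been measured in this assay. Relative to compound 2 the change is 2-carbamoylethyl in place of isopropyl on a saturated chain carbon bound to an amine nitrogen and a carbonyl carbon. For the measured compounds named here, no measured step bears on this place: the one step on record alters a saturated ring carbon of the shared core, not the chain carbon bound to an amine nitrogen and a carbonyl carbon, and it read within the scatter. Compound 1, compound 2 and compound 3 differ in both side chain and core, yet all their values fall within the scatter of one another, so nothing shown argues for a shift beyond the scatter in either direction, and the range must stay wide.

Compound 4 is therefore expected near compound 2, at an estimated 5600 nM with a range of 2500 nM to 13000 nM in this assay. The expected step is no change at the digits printed from compound 2 to compound 4 (within the scatter).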

Compound 4, half-maximal inhibitory concentration: 800 nM
Compound 4: the middle estimate sits 7.0-fold (0.85 log units) above what was measured, outside the stated range (below it).
By their numbers in this assay, from the lowest: compound 4; then compounds 3, 1 and 2 (each within the scatter of the next).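

Among the compounds shown here, the chain carbon bound to an amine nitrogen and a carbonyl carbon is a place where this assay responds: 2-carbamoylethyl in place of isopropyl gives a 7.0-fold lower number from compound 2 to compound 4 (0.85 log units; beyond the scatter) while the only earlier step, on a saturated ring carbon of the shared core, stayed within the scatter. The entering group brings a double bond outside aromatic rings, a hydrogen-bond donor, a hydrogen-bond acceptor and more heavy atoms than isopropyl, and this single step cannot separate which of these goes with the lower number. No measurement in hand offers an explanation for the step.

Still open, as far as these compounds go, is whether the lower number follows the terminal amide or the chain itself; a carboxylic acid in place of that amide, the shorter carbamoylmethyl and a plain butyl chain would tell these readings apart. Also open is whether 2-carbamoylethyl has the same effect on the differing cores of compound 1 and compound 3, since the step shown rests on the core of compound 2 alone.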